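From fluoro to methyl in a cell toxicity test

The source may report more compounds than this note shows. Statements on the series, on what has been measured and on what is new or still open speak of the compounds shown alone.

In an ADME assay on HepG2 cells (Homo sapiens) for cytotoxicity, read by MTT assay, with a stated time of 3 days (on this read-out lower numbers stand for higher toxicity in this test and higher numbers for lower toxicity in this test), compound 1 (`O=c1nc(NO)c(F)cn1[C@@H]1C[C@@H](O)[C@H](CO)O1`) gives 920000 nM. Compound 2 (`O=c1nc(NO)ccn1[C@@H]1CS[C@H](CO)O1`) gives 1320000 nM. Going by the values given here, these two numbers lie within the usual scatter of each other, so compound 1 stands level with the only other compound measured so far.

Compound 3 (`Cc1cn([C@@H]2C[C@@H](O)[C@H](CO)O2)c(=O)nc1NO`) is still waiting for its measurement. It is compound 1 with a single change: methyl in place of fluoro on an aromatic carbon. Among the compounds with values here, the two measured compounds differ in more than one place, so no measured step speaks directly to this swap. With so little to go on, no shift beyond the scatter is expected in this assay, in either direction. The expected move, a 1.1-fold higher number from compound 1 to compound 3 (0.04 log units; within the scatter), is small. For compound 3 the estimate is 1000000 nM, with an expected range from 350000 nM to 2800000 nM.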

Compound 3, half-maximal cytotoxic concentration: 490000 nM
Compound 3: the middle estimate sits 2.0-fold (0.31 log units) above what was measured, within the range that was stated.
By their numbers in this assay, from the lowest: compounds 3, 1 and 2 (each within the scatter of the next, the first and the last beyond it).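

In this assay, methyl in place of fluoro on an aromatic carbon, ortho to a hydroxyamino group, gives a 1.9-fold lower number from compound 1 to compound 3 (0.27 log units; within the scatter). Going by these compounds alone, this is the first measured step that changes only one place, and it stays within the usual scatter of repeated measurements, so this test cannot tell the two groups apart at this position. No measured evidence bears on what lies behind this result.

Fluoro and methyl are a single pair of small groups, so it remains open whether an amine, a carboxylic acid or a longer chain at the same position would move the number beyond the scatter. From the compounds shown here alone, it is also open whether the same swap would behave alike on the core of compound 2, which differs from compound 1 in more than one place.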